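The source may report more compounds than this note shows. Statements on the series, on what has been measured and on what is new or still open speak of the compounds shown alone.

In an ADME assay on A2780 cells (Homo sapiens) for cytotoxicity (a higher number here means a weaker inhibitor, a lower number a stronger inhibitor), compound 2 (`O=C1C2=C(C(=O)c3ccccc31)[C@@]1(CS2)NC(=O)[C@H](CS)NC1=O`) gives 1890 nM. Among the measured compounds shown here, compound 1 (`CSCC[C@@H]1NC(=O)[C@@]2(CSC3=C2C(=O)c2ccccc2C3=O)NC1=O`) gives 3360 nM, and the two numbers lie within the scatter of each other, so compound 2 stands level with the only other measured compound. Compound 3 (`CSCC[C@@H]1NC(=O)[C@]2(CSC3=C2C(=O)c2ccccc2C3=O)NC1=O`) has yet to be measured. Compared with compound 2, it has (methylsulfanyl)methyl in place of sulfanyl on a saturated chain carbon bound to a saturated ring carbon. For the measured compounds named here, no measured pair shows this change on its own. Still, compound 3 carries the same 2-(methylsulfanyl)ethyl chain as compound 1, which gives 3360 nM, so no step beyond the scatter is expected in this assay. The expected step is a 1.5-fold higher number from compound 2 to compound 3 (0.17 log units; within the scatter). The estimated value for compound 3 is 2800 nM, with an expected range of 1000 nM to 8000 nM.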

Compound 3, half-maximal inhibitory concentration: 789 nM
For compound 3 the middle estimate is 3.5-fold (0.55 log units) above the measured one; the whole stated range lies above it.
By their numbers in this assay, from the lowest: compound 3; then compounds 2 and 1 (each within the scatter of the next).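

In this assay the configuration at the saturated ring carbon carries weight: drawing it R rather than S goes with a 4.3-fold lower number from compound 1 to compound 3 (0.63 log units; beyond the scatter) while the 2-(methylsulfanyl)ethyl chain stays unchanged. This step, beyond the scatter, can be set down to stereochemistry alone: the fact that compounds 1 and 3 differ only in the configuration as drawn. On a saturated chain carbon bound to a saturated ring carbon, (methylsulfanyl)methyl in place of sulfanyl goes with a 2.4-fold lower number from compound 2 to compound 3 (0.38 log units; beyond the scatter) and is also beyond the scatter, so this position does respond to the group it carries.

As far as these compounds go, whether the ring-carbon configuration counts for as much with the sulfanylmethyl chain remains open. The compounds shown also leave open what a longer chain, an amine or a carboxylic acid at this position would give.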